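Chain extension and expected solubility for compound 3

The source may report more compounds than this note shows. Statements on the series, on what has been measured and on what is new or still open speak of the compounds shown alone.

Compound 1, with the structure `CCCCCCCCCCCCCCSCC(COP(=O)(O)OP(=O)(O)OC[C@H]1OC(n2ccc(N)nc2=O)[C@@H](O)[C@@H]1O)OC(=O)CCCCCCCCCCCCC`, stands at the top of the numbers shown. In an ADME assay for solubility (on this read-out higher numbers stand for higher solubility and lower numbers for lower solubility), compound 1 gives > 60000000 nM, which is a limit of the assay rather than a measured number, as recorded in the limit of > 60000000 nM in this assay, at which 1 of the 2 values shown sits. Within the data shown here, its one measured partner is compound 2, `CCCCCCCCCCCCCCCC(=O)OC(COP(=O)(O)OP(=O)(O)OC[C@H]1OC(n2ccc(N)nc2=O)[C@@H](O)[C@@H]1O)CSCCCCCCCCCCCCCC`. In this assay compound 2 gives 1500000 nM. Among the measured compounds shown here, the only measured step, an at least 40-fold lower number from compound 1 to compound 2 (1.60 log units; beyond the scatter), is therefore large and points downward, though its exact size is open because compound 1 sits at a limit.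

Compound 3, `CCCCCCCCCCCCCCCCCCSCC(COP(=O)(O)OP(=O)(O)OC[C@H]1OC(n2ccc(N)nc2=O)[C@@H](O)[C@@H]1O)OC(=O)CCCCCCCCCCCCC`, has not yet been measured. It differs from compound 1 by butyl in place of hydrogen on a saturated chain carbon, ten or more bonds along the chain from a sulfur. The measured step also adds carbon to a saturated chain carbon far along a chain, so it bears on this change; here the added group is butyl rather than ethyl, and it sits on the chain counted from a sulfur. Compound 3 is expected to show a downward step an at least 120-fold lower number from compound 1 to compound 3 (2.07 log units; beyond the scatter), landing near 500000 nM with a range from 50000 nM to 10000000 nM.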

Compound 3, solubility: > 62000000 nM
Compound 3: a limit, no number; the forecaster's own chance of this, stated with the estimate: 15%; middle value at least 120-fold (2.09 log units) away from the limit.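

In this assay compound 3 gives > 62000000 nM, which is a limit of the assay and not a number. Compound 1 likewise gives a limit, > 60000000 nM. The step between compound 1 and compound 3 cannot be read from these two limits. The compounds shown leave open how far, and in which direction, butyl in place of hydrogen moves the read-out.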